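The compounds below may be only part of what the source reports. "The series", "measured", "known", "first", "only" and "open" are said of these compounds alone.

Compound 1 `Cc1noc(Cc2ccc3[nH]cc([C@H]4C[C@H](N(C)C)C4)c3c2)n1` was tested in an assay on CHO-K1 cells for binding affinity to 5-hydroxytryptamine receptor 1D (Homo sapiens) (a lower number here means a stronger inhibitor, a higher number a weaker inhibitor), where compound 1 gives 933 nM. Within the data shown here, only one other compound has been measured so far: compound 2 `N[C@H]1C[C@H](c2c[nH]c3ccc(Oc4ccccc4)cc32)C1`, which in this assay gives 14.5 nM. Of these two numbers, compound 1 has the higher one, so among the measured compounds it is the weaker binder. Compound 2 differs from it in more than one place, however, so the two values show only that the gap between them is wide, not which part of the structure accounts for it.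

Compound 3 `Cc1noc(-c2ccc3[nH]cc([C@H]4C[C@H](N(C)C)C4)c3c2)n1` has not yet been measured. It differs from compound 1 in a single place: 3-methyl-1,2,4-oxadiazol-5-yl in place of (3-methyl-1,2,4-oxadiazol-5-yl)methyl on an aromatic carbon. The oxadiazole ring is thus attached directly to the aromatic carbon of the shared core. Among the measured compounds shown here, no measured pair shows what such a change does here, so there is no step to lean on. The expected step, a 1.3-fold lower number from compound 1 to compound 3 (0.12 log units; within the scatter), is small and may not rise beyond the scatter. On that basis compound 3 is estimated to give 700 nM in this assay, with a likely range from 150 nM to 3000 nM.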

Compound 3, half-maximal inhibitory concentration: 562 nM
Estimate against measurement, compound 3: 1.2-fold (0.10 log units) above; the measured number falls inside the stated range.
By their numbers in this assay, from the lowest: compound 2; then compounds 3 and 1 (each within the scatter of the next).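

Among these compounds, compound 1 and compound 3 form the first pair here that differ in one place, so they give the first direct reading of this position in this assay. Replacing (3-methyl-1,2,4-oxadiazol-5-yl)methyl with 3-methyl-1,2,4-oxadiazol-5-yl on this aromatic carbon gives a 1.7-fold lower number from compound 1 to compound 3 (0.22 log units; within the scatter), so attaching the ring directly to the shared core produces no difference that can be told from the usual variation between repeated measurements. Nothing available explains why the two compounds read alike, and the pair alone cannot show how the link affects binding.

Among the compounds shown here, this single pair tests only one small change to the link, so it leaves open whether a longer chain between the oxadiazole ring and the aromatic carbon would also leave the number within the scatter. It also leaves open whether a different group at the same place, such as an amide or a carboxylic acid, would move the number beyond the scatter in either direction.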